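A Chloro Group in Place of Hydrogen on Compound 2

The source may hold more compounds than are shown below. What is called first, only, known or untested is meant among the compounds shown, and "the series" means these compounds.

Compound 1 `COc1ccc(-c2nc(SCC(=O)c3sc(-c4ccccc4)nc3C)[nH]c(=O)c2C#N)cc1` — 1.08%
Compound 2 `Cc1nc(-c2ccccc2)sc1C(=O)CSc1nc(-c2ccccc2)c(C#N)c(=O)[nH]1` — 9.23%
Compound 3 `COc1ccc(-c2nc(SCC(=O)c3sc(-c4ccccc4)nc3C)[nH]c(=O)c2C#N)cc1OC` — 6.48%

In a functional assay on U-87MG ATCC cells for antiproliferative activity against U-87 MG (Homo sapiens), read by MTT assay, with a stated time of 48 h, tested at 100 uM (a higher number here means a weaker effect of the compound at the concentration tested, a lower number a stronger effect), compound 2 gives 9.23%, the greatest of the three numbers, yet its distance to the other two compounds is small: a number 2.8 percentage points lower from compound 2 to compound 3 (within the scatter) and a number 8.2 percentage points higher from compound 1 to compound 2 (within the scatter). The third step among the measured compounds, a number 5.4 percentage points higher from compound 1 to compound 3 (within the scatter), is likewise within the scatter. All three compounds share one core and differ only in methoxy groups on one phenyl ring, and none of these exchanges moves the read-out beyond the usual repeat-to-repeat spread.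

Compound 4 `Cc1nc(-c2ccc(Cl)cc2)sc1C(=O)CSc1nc(-c2ccccc2)c(C#N)c(=O)[nH]1` is the unmeasured member. Its change from compound 2 is chloro in place of hydrogen on an aromatic carbon. Going by the values given here, no measured step introduces chloro, and no measured step touches the ring on which this change sits; the steps at hand concern methoxy on the other phenyl and are all within the scatter. They therefore give no ground to expect a step beyond the scatter in this assay in either direction. Compound 4 is estimated at 8%, with a range from 0% to 20%, so that the expected step is a number 1.2 percentage points lower from compound 2 to compound 4 (within the scatter).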

Compound 4, a percentage reported as activity, at one concentration (the size of the read-out at that concentration, not a potency): 11.4%
The estimate for compound 4 lay 3.4 percentage points below the measured number, within the range that was stated.
By their numbers in this assay, from the lowest: compounds 1, 3, 2 and 4 (each within the scatter of the next, the first and the last beyond it).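

In this assay, replacing hydrogen with chloro gives a number 2.2 percentage points higher from compound 2 to compound 4 (within the scatter). Going by these compounds alone, the earlier steps all concerned methoxy groups on the other phenyl, so this is the first reading of a change on this ring: with phenyl turned into 4-chlorophenyl, one chlorine atom on an aromatic carbon, para to a large group, leaves the read-out within the usual spread at the single concentration tested. No measurement at hand accounts for this result or says what the chloro group does here.

The compounds shown leave open whether a different group at this same position, such as an amine, a carboxylic acid or a longer alkyl chain, would also stay within the scatter or would produce a step beyond it. They also do not tell whether chloro would behave the same way together with the methoxy groups of compound 1 or compound 3, or whether compound 2 and compound 4 would remain this close at concentrations lower than the one used here.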